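Replacing a Hydroxyl-Bearing Aryl Ether with an Indanyl Ether

A few compounds are considered here, and "the series" means these few. Any claim that something is new, unique, unknown or untested is made for them only; others in the source may bear on it.

Measured compounds:
Compound 1 `COc1ccc(-c2ccc(Oc3ccccc3C)c(NC(=O)Nc3ccc(C)cc3)c2)cc1C(=O)O` gives 840 nM in an assay on HeLa cells for inhibition of Indoleamine 2,3-dioxygenase 1 (Homo sapiens), with a stated time of 20 h; on this read-out lower numbers stand for stronger inhibition and higher numbers for weaker inhibition.
Compound 2 `COc1ccc(-c2ccc(Oc3ccccc3C#N)c(NC(=O)Nc3ccc(C)cc3)c2)cc1C(=O)O` gives 6000 nM in this assay.
Compound 3 `COc1ccc(-c2ccc(Oc3ccccc3C(C)(C)CO)c(NC(=O)Nc3ccc(C)cc3)c2)cc1C(=O)O` gives 2400 nM in this assay.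

Among these three, compound 3 stands second highest; compound 2 sits above it, as shown by a 2.5-fold lower number from compound 2 to compound 3 (0.40 log units; beyond the scatter), and compound 1 sits below it, as shown by a 2.9-fold higher number from compound 1 to compound 3 (0.46 log units; beyond the scatter).

Compound 4 `COc1ccc(-c2ccc(Oc3cccc4c3CCC4)c(NC(=O)Nc3ccc(C)cc3)c2)cc1C(=O)O` differs from compound 3 in one place: 2,3-dihydro-1H-inden-4-yl in place of 2-(1-(hydroxymethyl)-1-methylethyl)phenyl on an oxygen on an aromatic ring. Going by the values given here, the step that bears most on this change is the one from compound 1 to compound 3, a 2.9-fold higher number from compound 1 to compound 3 (0.46 log units; beyond the scatter), where a methyl gave way to the hydroxyl-bearing group and the number rose. The change to compound 4 removes that group again and brings in a fused hydrocarbon ring, so the number is expected to move back toward that of compound 1. Among the compounds with values here, no measured step covers a fused ring at this position, so the estimate is uncertain. Compound 4 is therefore expected to show a 2.2-fold lower number from compound 3 to compound 4 (0.34 log units; beyond the scatter), giving an estimated value of 1100 nM, with a range from 400 nM to 3000 nM.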

Compound 4, half-maximal inhibitory concentration: 280 nM
Beside the measured number, compound 4's estimate is 3.9-fold (0.59 log units) above it; the whole stated range lies above it.
By their numbers in this assay, from the lowest: compound 4; then compound 1; then compound 3; then compound 2.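

In this assay, the 2,3-dihydro-1H-inden-4-yl group on this oxygen does more than recover the ground lost with the hydroxyl-bearing group: the change shows a 3.0-fold lower number from compound 1 to compound 4 (0.48 log units; beyond the scatter), so the fused hydrocarbon ring goes past the 2-methylphenyl group as well. The other two comparisons are wider, with an 8.6-fold lower number from compound 3 to compound 4 (0.93 log units; beyond the scatter) and a 21-fold lower number from compound 2 to compound 4 (1.33 log units; beyond the scatter), which makes compound 4 the strongest inhibitor of the four and shows that this position accepts a fused ring on the aromatic ring. No supporting measurement here accounts for the gain.

The compounds shown leave open whether the size of the fused ring matters, as a six-membered tetrahydronaphthyl ring would test. They also leave open whether an amine or a carboxylic acid on the fused ring would keep this level of inhibition.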